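The source may report more compounds than this note shows. Statements on the series, on what has been measured and on what is new or still open speak of the compounds shown alone.

Measured so far in a functional assay on HepG2 cells (Homo sapiens) for inhibition, read by MTT assay, with a stated time of 48 h; a lower number here means a stronger inhibitor, a higher number a weaker inhibitor:
- compound 1, `COc1ccccc1-c1csc(N/N=C/c2ccc(F)c(F)c2)n1` — gives > 100000 nM, a limit of this assay, not a number.
- compound 2, `COc1cc(/C=N/Nc2nc(-c3cc(C(F)(F)F)cc(C(F)(F)F)c3)cs2)c(Br)c(Br)c1OC` — gives > 100000 nM, likewise a limit of this assay, not a number.

Both measured compounds share the hydrazone-linked thiazole core and both sit at the same limit; compound 1 therefore stands nowhere in particular among the numbers shown, since the limit of > 100000 nM in this assay, at which 2 of the 2 values shown sit, is all that has been recorded. Going by the values given here, no step between measured compounds is available, so nothing shows how a change on the aromatic carbon carrying the aryl group moves the read-out.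

Compound 3, `Fc1ccc(/C=N/Nc2nc(-c3ccc(F)c(F)c3)cs2)cc1F`, differs from compound 1 as follows: 3,4-difluorophenyl in place of 2-methoxyphenyl on an aromatic carbon. Given that compound 1 sits at a limit, the step from compound 1 to compound 3 is expected to show no change resolvable beyond the scatter, a number no higher from compound 1 to compound 3 (the limit leaves the size open). Compound 3 is therefore expected to give about 100000 nM in this assay, within a range of 30000 nM to 300000 nM, most probably again as a limit rather than a number.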

Compound 3, half-maximal inhibitory concentration: 26600 nM
The estimate for compound 3 lay 3.8-fold (0.58 log units) above the measured number; the whole stated range lies above it.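

In this assay, 3,4-difluorophenyl in place of 2-methoxyphenyl on the aromatic carbon next to the ring nitrogen gives an at least 3.7-fold lower number from compound 1 to compound 3 (0.57 log units; beyond the scatter), the first sign that this position can move the read-out at all. The value of compound 1 is a limit, so this step fixes only a minimum size. Compound 3 is the only compound shown with a number rather than a limit: the limit of > 100000 nM in this assay, at which 2 of the 3 values shown sit.

The change removes the methoxy group and brings in the fluorines in a single step, so the compounds shown do not separate the two contributions. As far as these compounds go, how an unsubstituted phenyl, or an aryl group carrying an amine or a carboxylic acid, would read at this position also remains open.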